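Aryl for cycloalkyl on the five-membered ring: compound 4

The source may report more compounds than this note shows. Statements on the series, on what has been measured and on what is new or still open speak of the compounds shown alone.

Measured in an assay on isolated protein for inhibition of proto-oncogene tyrosine-protein kinase receptor Ret (Homo sapiens), read by radiometric assay and 33P incorporation, in the presence of a further agent that is not named here; on this read-out higher numbers stand for weaker inhibition and lower numbers for stronger inhibition:
compound 1 `CC(C)n1nc(-c2cc(C3CCCCC3)on2)c2c(N)ncnc21` gives 910 nM
compound 2 `CC(C)n1nc(/C=N/OCc2ccccc2)c2c(N)ncnc21` gives 8330 nM
compound 3 `Nc1ncnc2c1c(-c1cc(C3CC3)on1)nn2C1CCOCC1` gives 5 nM

Compound 1 stands second highest of the three numbers: compound 2 sits above it, beyond the scatter, and compound 3 sits far below it, also beyond the scatter. Compound 4 `CC(C)n1nc(-c2cc(-c3ccc(F)cc3)on2)c2c(N)ncnc21` differs from compound 1 only by 4-fluorophenyl in place of cyclohexyl on an aromatic carbon. Among the compounds with values here, no measured pair isolates this change, so the expected step rests on the spread seen across compounds 1, 2 and 3 alone. The step of a 2.3-fold lower number from compound 1 to compound 4 (0.36 log units; beyond the scatter) is expected to be a modest move toward a lower number, only just beyond the scatter. For compound 4 the estimate in this assay is 400 nM, with a range from 80 nM to 2000 nM.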

Compound 4, half-maximal inhibitory concentration: 150 nM
Estimate against measurement, compound 4: 2.7-fold (0.43 log units) above, and the stated range covers the measured number.
By their numbers in this assay, from the lowest: compound 3; then compound 4; then compound 1; then compound 2.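

Within the data shown here, on the aromatic carbon next to the ring oxygen, 4-fluorophenyl in place of cyclohexyl brings a 6.1-fold lower number from compound 1 to compound 4 (0.78 log units; beyond the scatter) and gives the first single-change reading at this position. The position therefore accepts an aromatic ring as well as a non-aromatic one, and here the aromatic ring goes with stronger inhibition. Nothing at hand explains this step.

As far as these compounds go, the share of the fluorine stays open: phenyl without it would separate the ring change from the substituent, and a morpholine would test a ring containing nitrogen and oxygen. From the compounds shown here alone, whether the step carries over to the tetrahydropyranyl compound 3 also remains open.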